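This account rests on a few compounds, and the source may have more. Where it says the series, first, only, none or still open, it means among the compounds named here.

Working notes on the lactam series.

Compound 1 `O=C1COc2ccc(-c3cccc(NS(=O)(=O)c4ccc(F)cc4)c3)cc2N1c1ccccc1` carries a phenyl on the amide-type nitrogen of its ring core. For the measured compounds named here, in a functional assay on HepG2 cells (Homo sapiens) for antiproliferative activity, read by MTT assay, with a stated time of 72 h (a higher number here means a weaker inhibitor, a lower number a stronger inhibitor), compound 1 gives 30300 nM, the only numerical value in the set. Compound 2 `O=C1COc2ccc(-c3cnc(Cl)c(NS(=O)(=O)c4ccc(F)cc4)c3)cc2N1` is the second measured member. In this assay compound 2 returns > 40000 nM, which is a limit of the assay and not a number; the set therefore holds one value at the limit of > 40000 nM in this assay, at which 1 of the 2 values shown sits, and one read as a number. Going by the values given here, no pairwise step between measured compounds is available, so the pair says only that compound 1 falls within the measurable window and compound 2 does not.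

Compound 3 `O=C1COc2ccc(-c3cccc(NS(=O)(=O)c4ccc(F)cc4)c3)cc2N1` is the unmeasured target. Its difference from compound 1 is hydrogen in place of phenyl on an amide-type nitrogen in a ring. Compound 3 shares the core of compound 1 otherwise unchanged. Among the compounds with values here, no measured step informs this change, so the expected step of a 1.2-fold higher number from compound 1 to compound 3 (0.06 log units; within the scatter) is set as no more than the scatter, with a lean toward weaker inhibition given how close compound 1 already sits to the limit. Compound 3 is estimated at 35000 nM in this assay, expected range 12000 nM to 100000 nM.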

Compound 3, half-maximal inhibitory concentration: > 40000 nM
Compound 3 gave a limit, no number (the forecaster's own chance of this, stated with the estimate: 45%); middle value at least 1.1-fold (0.05 log units) away from the limit.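

For the compounds shown here, replacing the phenyl with hydrogen on the amide-type nitrogen in a ring gives the only step at this position, and in this assay it reads as an at least 1.3-fold higher number from compound 1 to compound 3 (0.12 log units; that floor lies within the scatter). Compound 3 gives > 40000 nM, which is a limit of the assay and not a number. The true size of the step therefore stays unknown, its printed floor does not separate the two compounds beyond the scatter, and compound 1 with its phenyl remains the only compound in the set with a numerical reading: the limit of > 40000 nM in this assay, at which 2 of the 3 values shown sit.

Whether a different group on this nitrogen, such as a methyl, a benzyl or a longer chain ending in an amine, would give a lower number than compound 1 stays open in the compounds shown. As far as these compounds go, it also stays open whether the full step from phenyl to hydrogen lies beyond the scatter, as neither the phenyl nor any other group at this position has yet been paired with a second numerical value.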